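Amide nitrogen substituent on the shared core, step to compound 4

A few compounds are considered here, and "the series" means these few. Any claim that something is new, unique, unknown or untested is made for them only; others in the source may bear on it.

Measured compounds:
compound 1 `CCc1ccc(NC(=O)c2cccc(/C=C3\CC(=O)N(c4ccccc4)C3=O)c2)cc1` gives > 100000 nM
compound 2 `O=C(NCc1ccccc1)c1cccc(/C=C2\CC(=O)N(c3ccccc3)C2=O)c1` gives > 100000 nM
compound 3 `O=C(NCC1CCCCC1)c1cccc(/C=C2\CC(=O)N(c3ccccc3)C2=O)c1` gives > 100000 nM

In an ADME assay on HCT-116 cells (Homo sapiens) for cytotoxicity, read by MTT assay, with a stated time of 72 h (a higher number here means a weaker inhibitor, a lower number a stronger inhibitor), compound 1 reports only a limit, > 100000 nM. In this assay compound 2 likewise reports only a limit, > 100000 nM. In this assay compound 3 also reports only a limit, > 100000 nM. The steps a step that the two limits leave unreadable from compound 1 to compound 2, a step that the two limits leave unreadable from compound 1 to compound 3 and a step that the two limits leave unreadable from compound 2 to compound 3 therefore carry no readable size, because of the limit of > 100000 nM in this assay, at which 3 of the 3 values shown sit. Compound 3 thus stands at the same limit as the other two.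

Compound 4 `CCOc1ccc(NC(=O)c2cccc(/C=C3\CC(=O)N(c4ccccc4)C3=O)c2)cc1` differs from compound 3 as 4-ethoxyphenyl in place of cyclohexylmethyl on an amide-type nitrogen. The three measured steps all exchange the group on the amide-type nitrogen between aryl and saturated variants, and none of them moves the value off the limit. Going by the values given here, no measured step suggests that the 4-ethoxyphenyl group would do otherwise. The expected step of a number no higher from compound 3 to compound 4 (the limit leaves the size open) is accordingly none beyond the scatter. Compound 4 is expected to give 100000 nM in this assay, within 30000 nM to 300000 nM, most probably again as a limit.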

Compound 4, half-maximal inhibitory concentration: 84800 nM
For compound 4 the middle estimate is 1.2-fold (0.07 log units) above the measured one; the measured number falls inside the stated range.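

In this assay the group on the amide-type nitrogen can bring a compound off the limit: compound 4, with 4-ethoxyphenyl, is the only compound shown that carries a number rather than a limit, and the others share one limit: the limit of > 100000 nM in this assay, at which 3 of the 4 values shown sit. Against the saturated and benzyl groups the change gives an at least 1.1-fold lower number from compound 3 to compound 4 (0.07 log units; that floor lies within the scatter) and an at least 1.1-fold lower number from compound 2 to compound 4 (0.07 log units; that floor lies within the scatter), while ethoxy in place of ethyl on an aromatic carbon gives an at least 1.1-fold lower number from compound 1 to compound 4 (0.07 log units; that floor lies within the scatter). Each of these is only a floor, and the steps among compound 1, compound 2 and compound 3 cannot be read.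

Going by these compounds, the true size of the ethoxy-for-ethyl step stays open. Also open, on these data alone, is whether an amine or a carboxylic acid on the aromatic ring, or a longer alkoxy chain in place of ethoxy, would move the number further from that of compound 4.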